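Replacing octylsulfanyl in compound 2 with hydrogen

The source may report more compounds than this note shows. Statements on the series, on what has been measured and on what is new or still open speak of the compounds shown alone.

For the measured compounds named here, in an ADME assay on PBMC cells (Homo sapiens) for cytotoxicity, read by MTT assay (on this read-out higher numbers stand for weaker inhibition and lower numbers for stronger inhibition), compound 1 (`CC1=CCC[C@H]2[C@](C)(CC3=CC(=O)C(SC(C)(C)C)=CC3=O)[C@@H](C)CC[C@]12C`) gives 21700 nM, the only number so far. Compound 2 (`CCCCCCCCSC1=CC(=O)C(C[C@]2(C)[C@@H](C)CC[C@]3(C)C(C)=CCC[C@@H]23)=CC1=O`) has no place on this scale: the entry for compound 2 reads "not determined" (no result reported), so it offers no starting value. Compound 3 (`CC1=CCC[C@H]2[C@](C)(CC3=CC(=O)C=CC3=O)[C@@H](C)CC[C@]12C`) departs from compound 2 by a single change: hydrogen in place of octylsulfanyl on a double-bonded ring carbon. Going by the values given here, no measured step exists, so the data cannot set the size of this change in this assay. A modest move towards stronger inhibition is expected, judged only against the value of compound 1 (21700 nM) , and it may stay within the usual scatter. For compound 3 the estimated half-maximal inhibitory concentration is 14000 nM (expected range 4000 nM to 45000 nM).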

Compound 3, half-maximal inhibitory concentration: 4800 nM
Beside the measured number, compound 3's estimate is 2.9-fold (0.46 log units) above it; low and high end bracket the measured number.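

In this assay this position now has its first measured step, a 4.5-fold lower number from compound 1 to compound 3 (0.66 log units; beyond the scatter), with hydrogen in place of (tert-butyl)sulfanyl on a double-bonded ring carbon. On the shared core, then, the (tert-butyl)sulfanyl group is not needed for inhibition on this read-out, and of this pair the compound carrying hydrogen gives the stronger inhibition. No other information on this series accounts for the size of this step.

The step between compound 2 and compound 3 cannot be read, so octylsulfanyl remains unplaced relative to hydrogen or (tert-butyl)sulfanyl. With only one readable pair, the compounds shown leave open how a methylsulfanyl group, an amine or a carboxylic acid on this ring carbon would compare with hydrogen.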